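The compounds below may be only part of what the source reports. "The series", "measured", "known", "first", "only" and "open" are said of these compounds alone.

In an in vitro ADME assay on microsomes from liver (Homo sapiens) for metabolic stability (a higher number here means faster removal of the compound, a lower number slower removal), compound 3 `O=C(NCC1(O)CCCCCC1)c1cc(-c2ncc(F)cn2)ccc1Cl` gives 21 mL/min/kg, the lowest of the three measured numbers. Compound 1 `O=C(NCC1(O)CCCCCC1)c1cc(-c2ccc(Cl)cn2)ccc1Cl` gives 52 mL/min/kg, and compound 2 `COc1ccc(-c2ccc(Cl)c(C(=O)NCC3(O)CCCCCC3)c2)nc1` gives 122 mL/min/kg; the measured steps were a 2.5-fold lower number from compound 1 to compound 3 (0.39 log units; beyond the scatter) and a 5.8-fold lower number from compound 2 to compound 3 (0.76 log units; beyond the scatter), while between the other two there was a 2.3-fold higher number from compound 1 to compound 2 (0.37 log units; beyond the scatter). Compound 4 `O=C(NCC1(O)CCC(F)(F)CC1)c1cc(-c2ncc(F)cn2)ccc1Cl` differs from compound 3 by 4,4-difluoro-1-hydroxycyclohexyl in place of 1-hydroxycycloheptyl on a saturated chain carbon bound to an amide-type nitrogen. Within the data shown here, none of the measured steps touches this part of the molecule; all three concern the aromatic group, so they offer no direct guide, and only a step no larger than those already seen is expected, with the estimate a 1.4-fold lower number from compound 3 to compound 4 (0.15 log units; within the scatter). Compound 4 is therefore expected to give about 15 mL/min/kg, most likely between 7 mL/min/kg and 35 mL/min/kg.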

Compound 4, clearance: < 8.8 mL/min/kg
Compound 4: a limit, no number (the forecaster's own chance of this, stated with the estimate: 5%); middle value at least 1.7-fold (0.23 log units) away from the limit.
By their numbers in this assay, from the lowest: compound 3; then compound 1; then compound 2. At a limit, below all of these: compound 4.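

Among these compounds, every earlier step changed the aromatic group; this is the first to change the group on the saturated chain carbon, and it shows that this position also affects the read-out in this assay. Putting 4,4-difluoro-1-hydroxycyclohexyl in place of 1-hydroxycycloheptyl gives an at least 2.3-fold lower number from compound 3 to compound 4 (0.37 log units; beyond the scatter). The result for compound 4 is a limit and not a number: the limit of < 8.8 mL/min/kg in this assay, at which 1 of the 4 values shown sits.

This change alters ring size and adds fluorine together, and the compounds shown do not separate the two. Also open, as far as these compounds go, is how plain 1-hydroxycyclohexyl, or an amine in place of the hydroxyl, would behave here.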